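The compounds below may be only part of what the source reports. "The series", "measured", "known", "first", "only" and "open" are said of these compounds alone.

The compounds measured so far in a functional assay on SK-OV-3 cells (Homo sapiens) for inhibition, read by CCK-8 assay, with a stated time of 70 h; a higher number here means a weaker inhibitor, a lower number a stronger inhibitor:

Compound 1 `c1ccc(COc2ccc(OCCOCCNc3ccccc3)cc2)cc1` gives > 100000 nM, which is a limit of the assay and not a number.
Compound 2 `c1ccc(COc2ccc(OCCOCCNc3cc[nH]c3)cc2)cc1` gives 11300 nM.
Compound 3 `Nc1ccc(COc2ccc(OCCOCCNC3CCCC3)cc2)cc1` gives 31700 nM.

Compound 3 stands highest of the two numbers obtained; its nearest neighbour is compound 2, and the gap between them lies beyond the scatter. Compound 1 reaches only a limit, (the limit of > 100000 nM in this assay, at which 1 of the 3 values shown sits). Compound 4 `CCOc1ccc(OCCOCCNC2CCCC2)cc1` differs from compound 3 in one place: methyl in place of 4-aminophenyl on a saturated chain carbon bound to an oxygen on an aromatic ring. Among the measured compounds shown here, the only single-change step measured is an at least 8.8-fold lower number from compound 1 to compound 2 (0.94 log units; beyond the scatter), and it alters the group on the amine nitrogen rather than the saturated chain carbon bound to an oxygen on an aromatic ring, so it does not bear directly on this change. For the measured compounds named here, no measured pair speaks to the loss of the 4-aminophenyl. It is therefore expected that the number for compound 4 rises, a 1.9-fold higher number from compound 3 to compound 4 (0.28 log units; within the scatter), with compound 3 already at 31700 nM as the starting point. Compound 4 is estimated at 60000 nM, in a range from 15000 nM to 150000 nM.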

Compound 4, half-maximal inhibitory concentration: 90500 nM
Estimate against measurement, compound 4: 1.5-fold (0.18 log units) below; the measured number falls inside the stated range.
By their numbers in this assay, from the lowest: compound 2; then compound 3; then compound 4. At a limit, above all of these: compound 1.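

In this assay the position on the saturated chain carbon bound to an oxygen on an aromatic ring now has a measured effect: a 2.9-fold higher number from compound 3 to compound 4 (0.46 log units; beyond the scatter) follows when methyl replaces 4-aminophenyl, the same difference as (4-aminobenzyl)oxy to ethoxy. This is the first pair shown to change this place, as the only earlier step altered the group on the amine nitrogen, and it shows that the number responds to more than that group. Nothing given here accounts for the step.

The compounds shown leave open whether the difference rests with the aromatic ring or with its amine, which a plain phenyl or a 4-hydroxyphenyl on the core of compound 3 would help to separate. They also leave open how a longer alkyl chain would compare with methyl at this place.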